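The source may hold more compounds than are shown below. What is called first, only, known or untested is meant among the compounds shown, and "the series" means these compounds.

Measured so far in a functional assay on MGC-803 cells (Homo sapiens) for inhibition, read by MTT assay, with a stated time of 72 h; a lower number here means a stronger inhibitor, a higher number a weaker inhibitor:

- Compound 1 `O=C(Nc1ccccc1)C1CCN(C/C=C/c2ccccc2)CC1`: 57900 nM
- Compound 2 `CCCCCc1ccc(NC(=O)C2CCN(C/C=C/c3ccccc3)CC2)cc1`: 2550 nM
- Compound 3 `COc1ccccc1NC(=O)C1CCN(C/C=C/c2ccccc2)CC1`: 71200 nM

In this assay compound 3 gives 71200 nM and is level with compound 1 at 57900 nM, since the two lie within the scatter. Compound 2 stands well apart at 2550 nM.

Compound 4 `O=C(Nc1ccccn1)C1CCN(C/C=C/c2ccccc2)CC1` changes the group on the amide: pyridin-2-yl in place of 2-methoxyphenyl on an amide-type nitrogen. Put simply, pyridin-2-yl takes the place of 2-methoxyphenyl on an amide-type nitrogen.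

Two measured steps offer guidance. Adding methoxy to the ring of compound 1 gave a 1.2-fold higher number from compound 1 to compound 3 (0.09 log units; within the scatter), so losing that group is not expected to matter much. Adding pentyl gave a large change, a 23-fold lower number from compound 1 to compound 2 (1.36 log units; beyond the scatter), but compound 4 carries no pentyl, so this step offers no reason to expect a similar drop. For the measured compounds named here, no measured compound carries pyridin-2-yl, which leaves the estimate uncertain. No change beyond the scatter is expected, and the estimate is a 1.2-fold lower number from compound 3 to compound 4 (0.07 log units; within the scatter).

Compound 4 is expected at about 60000 nM, with an estimated range of 25000 nM to 130000 nM.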

Compound 4, half-maximal inhibitory concentration: 45200 nM
Compound 4: middle estimate off by 1.3-fold (0.12 log units), on the high side; the range from low to high includes it.
By their numbers in this assay, from the lowest: compound 2; then compounds 4, 1 and 3 (each within the scatter of the next).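

In this assay, the change on the amide-type nitrogen gives a 1.6-fold lower number from compound 3 to compound 4 (0.20 log units; within the scatter), and measured against the unsubstituted phenyl it gives a 1.3-fold lower number from compound 1 to compound 4 (0.11 log units; within the scatter). Pyridin-2-yl is the only group shown with a hetero atom in this aromatic ring, and so swapping a ring carbon for a nitrogen joins the methoxy change among the steps that stay within the scatter, while pentyl on compound 2 remains the one change that stands apart. No measurement here explains why these groups differ so little.

Open, from the compounds shown here alone, is whether a shorter chain such as propyl or a longer one such as octyl would behave like pentyl, and whether pentyl would act the same on the pyridin-2-yl ring. A charged group such as an amine or a carboxylic acid on the ring also remains untested in the compounds shown.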